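The source may report more compounds than this note shows. Statements on the series, on what has been measured and on what is new or still open speak of the compounds shown alone.

Measured compounds:
- Compound 1, `CCCCc1cn(C[C@H](O)[C@H]2OC(=O)C(OCc3ccccc3)=C2OCc2ccccc2)nn1`: in a functional assay on HepG2 cells (Homo sapiens) for antiproliferative activity, read by MTT assay, with a stated time of 72 h (a higher number here means a weaker inhibitor, a lower number a stronger inhibitor), compound 1 gives 32800 nM.
- Compound 2, `COc1ccccc1-c1cn(C/C=C2\OC(=O)C(OCc3ccccc3)=C2OCc2ccccc2)nn1`: in this assay compound 2 gives only a limit, > 100000 nM, not a number.

Going by the values given here, compound 1 carries the only numerical value in this assay; the one other value shown is a limit of the assay, (the limit of > 100000 nM in this assay, at which 1 of the 2 values shown sits), so compound 1 cannot be ranked against compound 2 beyond saying that compound 2 gives no number at all. Among the compounds with values here, no two measured compounds differ in a single place, so no measured step is available to lean on.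

Compound 3, `O=C1O[C@H]([C@@H](O)Cn2cc(CCO)nn2)C(OCc2ccccc2)=C1OCc1ccccc1`, has not yet been tested in this assay. It is compound 1 with one change: hydroxy in place of ethyl on a saturated chain carbon, two bonds along the chain from an aromatic carbon. Within the data shown here, with no comparable measured step to guide the size, the expectation rests on the weakness of compound 1 alone. The step from compound 1 to compound 3 in this assay is expected to be a mild weakening, a 1.7-fold higher number from compound 1 to compound 3 (0.22 log units; within the scatter), close to the edge of the usual scatter rather than clearly beyond it. Compound 3 is therefore expected to give about 55000 nM in this assay, within a range from 18000 nM to 160000 nM, with a real chance that only a limit is reported.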

Compound 3, half-maximal inhibitory concentration: 68100 nM
For compound 3 the middle estimate is 1.2-fold (0.09 log units) below the measured one; the range from low to high includes it.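

In this assay, going by these compounds alone, the change from 4-butyl-1H-1,2,3-triazol-1-yl to 4-(2-hydroxyethyl)-1H-1,2,3-triazol-1-yl provides the first measured step in this set: a 2.1-fold higher number from compound 1 to compound 3 (0.32 log units; beyond the scatter), a modest weakening. The chain position therefore has a measurable effect on the read-out, but swapping the outer ethyl for hydroxy does not remove activity altogether, as compound 3 still gives a number, 68100 nM. Compound 2 gives only a limit, not a number: the limit of > 100000 nM in this assay, at which 1 of the 3 values shown sits.

This single step cannot separate the effect of adding the hydroxy from that of shortening the chain, since both happen together in going from compound 1 to compound 3. Other groups at the same place, such as an unsubstituted ethyl chain, a longer chain ending in hydroxy, an amine or a carboxylic acid, would be needed to show which of the two matters and whether any replacement can give a stronger inhibitor than compound 1.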